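The source may hold more compounds than are shown below. What is called first, only, known or untested is meant among the compounds shown, and "the series" means these compounds.

Measured compounds:
compound 1, `Cc1nn(-c2ccccc2C(C)C)c2c1[C@@H](c1ccc(Oc3ccccc3)cc1)S[C@@H](C)C(=O)N2`: 1900 nM
compound 2, `CCOc1cccc(-c2ccc([C@H]3S[C@@H](C)C(=O)Nc4c3c(C)nn4-c3ccccc3C)cc2)c1`: 3500 nM

Among the measured compounds shown here, in an assay on isolated protein for agonist activity at Bile acid receptor (Homo sapiens), read by AlphaScreen, with a stated time of 30 min (on this read-out higher numbers stand for an effect only at larger amounts of compound and lower numbers for an effect already at smaller amounts), compound 1 gives 1900 nM, the lower of the two numbers known here, while compound 2 gives 3500 nM; the two values lie within the scatter of each other, so neither compound can be set above the other.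

Compound 3, `Cc1ccc(-n2nc(C)c3c2NC(=O)[C@H](C)S[C@@H]3c2ccc(Oc3ccccc3)cc2)cc1`, is still to be measured. It differs from compound 1 in one place: 4-methylphenyl in place of 2-isopropylphenyl on an aromatic nitrogen. For the measured compounds named here, no comparable step between measured compounds is known, so the direction of this change rests on no measured pair. The step from compound 1 to compound 3 is expected to be small, a 1.3-fold higher number from compound 1 to compound 3 (0.12 log units; within the scatter), within the scatter. For compound 3 the estimate is 2500 nM, with a range from 800 nM to 8000 nM.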

Compound 3, half-maximal effective concentration: 3400 nM
Beside the measured number, compound 3's estimate is 1.4-fold (0.13 log units) below it; measured number inside the range.
By their numbers in this assay, from the lowest: compounds 1, 3 and 2 (each within the scatter of the next).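

In this assay, 4-methylphenyl in place of 2-isopropylphenyl on the aromatic nitrogen comes with a 1.8-fold higher number from compound 1 to compound 3 (0.25 log units; within the scatter), the first step measured at this position. This exchange, which leaves 7 heavy atoms where 9 stood, therefore cannot be told apart from no effect on the number. Nothing available explains this result.

Going by these compounds, because both the alkyl group and its place on the phenyl ring differ in this one step, their separate contributions stay open. So does the outcome with a carboxylic acid, an amine or a longer chain on this ring.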